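The source may report more compounds than this note shows. Statements on the series, on what has been measured and on what is new or still open speak of the compounds shown alone.

In an in vitro ADME assay on microsomes (Mus musculus) for metabolic stability (a lower number here means that the compound disappears faster, a higher number that the compound lasts longer), three related compounds have been measured. Compound 1 `Cc1c2c(n3c1CCN(C(=O)[C@H](C)N)CC[C@H](C)Nc1cc-3ccc1C(N)=O)CC(C)(C)CC2=O` gives > 0.5 h, which is a limit of the assay and not a number. Compound 2 `CC[C@H](N)C(=O)N1CCc2c(C)c3c(n2-c2ccc(C(N)=O)c(c2)N[C@@H](C)[C@H](C)C1)CC(C)(C)CC3=O` gives 0.383 h. Compound 3 `Cc1c2c(n3c1CCN(C(=O)[C@@H](N)C(C)C)C[C@@H](C)[C@H](C)Nc1cc-3ccc1C(N)=O)CC(C)(C)CC2=O` gives 0.133 h, the lowest number among those shown. For the measured compounds named here, only one measured step connects any of them: a 2.9-fold lower number from compound 2 to compound 3 (0.46 log units; beyond the scatter). That step is a methyl in place of hydrogen on a saturated chain carbon bound to two saturated chain carbons, so it offers no direct measure of a change on a carbonyl carbon.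

Compound 4 `Cc1c2c(n3c1CCN(C(=O)C1(N)CCCC1)C[C@@H](C)[C@H](C)Nc1cc-3ccc1C(N)=O)CC(C)(C)CC2=O` differs from compound 3 by 1-aminocyclopentyl in place of 1-amino-2-methylpropyl on a carbonyl carbon. Going by the values given here, no measured step covers this exchange, so the modest step from the methyl gives only a rough sense of scale, and no clear direction can be drawn from it. The expected step, a 1.3-fold higher number from compound 3 to compound 4 (0.11 log units; within the scatter), is therefore estimated to stay within the scatter in this assay. For compound 4, the expected half-life is 0.17 h, with an estimated range from 0.07 h to 0.4 h.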

Compound 4, half-life: 0.0833 h
Estimate against measurement, compound 4: 2.0-fold (0.31 log units) above, and the stated range covers the measured number.
By their numbers in this assay, from the lowest: compounds 4 and 3 (each within the scatter of the next); then compound 2. At a limit, above all of these: compound 1.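

In this assay the exchange on this carbonyl carbon gives a 1.6-fold lower number from compound 3 to compound 4 (0.20 log units; within the scatter) and so does not separate 1-aminocyclopentyl from 1-amino-2-methylpropyl. Measured against 1-aminopropyl, the same ring gives a 4.6-fold lower number from compound 2 to compound 4 (0.66 log units; beyond the scatter) and thus shows that the earlier drop seen with the added methyl is not unique to that group: among the three compounds that differ only at this place, compound 2 keeps the highest number, and none of them goes against this. Nothing shown here gives a reason for these numbers.

Going by these compounds, whether 1-aminocyclopropyl or 1-aminocyclohexyl on this carbonyl carbon would fall with compound 4 or with compound 2 remains open. Also open, on these data alone, is whether a shorter chain, such as aminomethyl, would give a higher number than compound 2 does.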